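A Larger Group on the Ring Amine of Compound 1

The source may hold more compounds than are shown below. What is called first, only, known or untested is meant among the compounds shown, and "the series" means these compounds.

Compound 1 `CN1CC[C@H](N(C)C(=O)N2CC[C@H](n3cnc4cc(-c5ccc(OC(F)(F)F)cc5)sc4c3=O)C2)C1` is measured in an assay on isolated protein for binding affinity to melanin-concentrating hormone receptor 1 (Homo sapiens) (on this read-out higher numbers stand for weaker inhibition and lower numbers for stronger inhibition), where compound 1 gives 39 nM. Among the three measured compounds it holds the second highest number: compound 2 `CCOc1ccc(-c2cc3ncn([C@H]4CCN(C(=O)N(C)[C@H]5CCN(C)C5)C4)c(=O)c3s2)c(Cl)c1` gives 26 nM, and a 1.5-fold lower number from compound 1 to compound 2 (0.18 log units; within the scatter). Compound 3 `CN1CC[C@H](N(C)C(=O)N2CC[C@H](n3cnc4cc(-c5ccc6c(c5)OCCO6)sc4c3=O)C2)C1` gives 143 nM, and a 3.7-fold higher number from compound 1 to compound 3 (0.56 log units; beyond the scatter); likewise a 5.5-fold higher number from compound 2 to compound 3 (0.74 log units; beyond the scatter). All three of these steps alter only the aryl group on the shared core and leave the remainder of the molecule untouched.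

Compound 4 `CN(C(=O)N1CC[C@H](n2cnc3cc(-c4ccc(OC(F)(F)F)cc4)sc3c2=O)C1)[C@H]1CCN(C2CCOCC2)C1` differs from compound 1 at a different place: oxan-4-yl in place of methyl on an amine nitrogen in a ring, so that 1-methylpyrrolidin-3-yl becomes 1-(oxan-4-yl)pyrrolidin-3-yl. Among the compounds with values here, none of the measured steps touches this position, and the measured compounds offer no precedent for a change at the amine nitrogen in a ring. Within the data shown here, with no such precedent, the expectation is a step of no clear size beyond the scatter, in either direction. Compound 4 is therefore expected to give about 45 nM, within a range from 15 nM to 150 nM, which corresponds to an expected 1.2-fold higher number from compound 1 to compound 4 (0.06 log units; within the scatter).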

Compound 4, inhibition constant: 18 nM
Compound 4: middle estimate off by 2.5-fold (0.40 log units), on the high side, and the stated range covers the measured number.
By their numbers in this assay, from the lowest: compounds 4, 2 and 1 (each within the scatter of the next, the first and the last beyond it); then compound 3.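

Within the data shown here, the earlier compounds varied only the aryl group, so this is the first reading at the amine nitrogen in the ring. With oxan-4-yl in place of methyl, this assay shows a 2.2-fold lower number from compound 1 to compound 4 (0.34 log units; beyond the scatter), so a far bigger group with a ring of its own is accepted at this position and the number falls modestly rather than rising. Nothing available on this series accounts for the shift.

The compounds shown leave open whether the ring oxygen of oxan-4-yl matters or the ring alone is enough, a question that a cyclohexyl group, a piperidin-4-yl group or a short chain such as isopropyl on the same nitrogen would address. They also leave open whether the same change would carry over to the 2-chloro-4-ethoxyphenyl group of compound 2.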